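Hydroxy in place of dimethylamino on the aryl ring

The compounds below may be only part of what the source reports. "The series", "measured", "known", "first", "only" and "open" are said of these compounds alone.

compound 1 `Cn1c(=O)c2nc(-c3cccc(F)c3)[nH]c2n(C)c1=O`: 4 nM
compound 2 `CN(C)c1cccc(-c2nc3c(=O)n(C)c(=O)n(C)c3[nH]2)c1`: 80 nM

Of the compounds shown here, two have numbers so far. Among the compounds with values here, in an assay for binding affinity to adenosine receptor A1 (Bos taurus) (a lower number here means a stronger inhibitor, a higher number a weaker inhibitor), compound 2 stands at the higher of the two; its only neighbour is compound 1, and the step of a 20-fold higher number from compound 1 to compound 2 (1.30 log units; beyond the scatter) separates them, so the exchange of fluoro for dimethylamino at this position raised the number well beyond the scatter.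

Compound 3 `Cn1c(=O)c2nc(-c3cccc(O)c3)[nH]c2n(C)c1=O` has not yet been measured. Relative to compound 2 the change is hydroxy in place of dimethylamino on an aromatic carbon. Within the data shown here, the single measured step that touches this position is a 20-fold higher number from compound 1 to compound 2 (1.30 log units; beyond the scatter), and the fluoro-bearing compound 1 gives 4 nM. Since removing the dimethylamino group returns toward the situation of compound 1, a move downward rather than a further rise is expected, though how far is uncertain. Compound 3 is therefore expected at 12 nM, within 3 nM to 45 nM, which amounts to an expected step of a 6.7-fold lower number from compound 2 to compound 3 (0.82 log units; beyond the scatter).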

Compound 3, half-maximal inhibitory concentration: 6 nM
For compound 3 the middle estimate is 2.0-fold (0.30 log units) above the measured one; the range from low to high includes it.
By their numbers in this assay, from the lowest: compounds 1 and 3 (each within the scatter of the next); then compound 2.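

In this assay, hydroxy on this aromatic carbon, meta to a large group, takes the number back down from the dimethylamino level (a 13-fold lower number from compound 2 to compound 3 (1.12 log units; beyond the scatter)), so the earlier rise is not a feature of every replacement of fluoro here. Hydroxy and fluoro cannot be told apart at this position (a 1.5-fold higher number from compound 1 to compound 3 (0.18 log units; within the scatter)), which leaves dimethylamino as the only one of the three groups that stands apart from the others, beyond the scatter. Nothing on hand accounts for the gap between dimethylamino and the other two groups.

Going by these compounds, whether an unsubstituted amine or a methoxy group would sit with dimethylamino or with hydroxy and fluoro remains open, and the same holds for a carboxylic acid. The compounds shown also leave open whether these three groups would rank the same way elsewhere on the aromatic ring.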